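Selenocyanate carbamates: para substituent swap, cytotoxicity notes

The compounds below may be only part of what the source reports. "The series", "measured", "known", "first", "only" and "open" are said of these compounds alone.

Measured so far in an ADME assay on 184B5 cells (Homo sapiens) for cytotoxicity, read by MTT assay, with a stated time of 72 h; on this read-out lower numbers stand for stronger inhibition of growth and higher numbers for weaker inhibition of growth:
Compound 1 `COc1ccc(OC(=O)Nc2ccc([Se]C#N)cc2)cc1` gives 19200 nM.
Compound 2 `N#C[Se]c1ccc(NC(=O)Oc2ccc(F)cc2)cc1` gives 29500 nM.
Compound 3 `N#C[Se]c1ccc(NC(=O)OCc2ccc([N+](=O)[O-])cc2)cc1` gives 18000 nM.

Compound 2 sits at the upper edge of these three numbers, but the gap to compound 1, a 1.5-fold higher number from compound 1 to compound 2 (0.19 log units; within the scatter), is within the scatter, and the gap to compound 3 is of the same size and likewise within the scatter. Among the measured compounds shown here, no compound in this set is separated from another beyond the scatter in this assay.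

Compound 4 `Cc1ccc(OC(=O)Nc2ccc([Se]C#N)cc2)cc1` differs from compound 2 in one place: methyl in place of fluoro on an aromatic carbon. For the measured compounds named here, the only measured step that bears on this position is the one from compound 1 to compound 2, where methoxy was replaced by fluoro, and that step stayed within the scatter. A second swap at the same position, to methyl, is therefore expected to leave the number in this assay roughly where compound 2 stands, with no step beyond the scatter in either direction.

For compound 4 the expected value in this assay is 22000 nM, with a range from 11000 nM to 44000 nM. The estimated step from compound 2 to compound 4 is a 1.3-fold lower number from compound 2 to compound 4 (0.13 log units; within the scatter), within the scatter.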

Compound 4, concentration for total growth inhibition: 8700 nM
Estimate against measurement, compound 4: 2.5-fold (0.40 log units) above; measured number below the stated range.
By their numbers in this assay, from the lowest: compound 4; then compounds 3, 1 and 2 (each within the scatter of the next).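

This position is not silent in this assay: methyl gives (a 3.4-fold lower number from compound 2 to compound 4 (0.53 log units; beyond the scatter)) and also (a 2.2-fold lower number from compound 1 to compound 4 (0.34 log units; beyond the scatter)), so both steps lie beyond the scatter, while the swap of methoxy for fluoro at the same place stayed within it (a 1.5-fold higher number from compound 1 to compound 2 (0.19 log units; within the scatter)). Among the groups on this aromatic carbon, para to a large group, methyl is therefore the first to set itself apart from the others, and it does so against both fluoro and methoxy. Nothing measured in this set bears on what lies behind the difference.

On these data alone, whether the lower number belongs to methyl alone or carries over to ethyl or a longer chain remains open. Also open, as far as these compounds go, is how chloro, an amine or a plain hydrogen at this same place would compare with methyl.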